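Solubility notes on a fused bicyclic amine series

The source may report more compounds than this note shows. Statements on the series, on what has been measured and on what is new or still open speak of the compounds shown alone.

Measured so far in a physicochemical assay for solubility, using the shake flask method, in phosphate buffer, measured as kinetic solubility, with a stated time of 20 h, at pH 6.5; on this read-out higher numbers stand for higher solubility and lower numbers for lower solubility:
- compound 1, `Fc1ccc(Nc2cc3[nH]c(-c4cccc(C(F)(F)F)c4)nc3cn2)nc1`: < 5000 nM, a limit of the assay and not a number
- compound 2, `FC(F)(F)c1ccc(Nc2cc3[nH]c(-c4cccc(C(F)(F)F)c4)nc3cn2)nc1`: < 5000 nM, also a limit of the assay and not a number
- compound 3, `FC1(F)CCC(c2nc3cnc(Nc4ccc(C(F)(F)F)cn4)cc3[nH]2)CC1`: 99000 nM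

Among the measured compounds shown here, compound 3 carries the only number in this set; the other two values are limits, as recorded by the limit of < 5000 nM in this assay, at which 2 of the 3 values shown sit. For the measured compounds named here, the two cores differ as 4,4-difluorocyclohexyl in place of 3-(trifluoromethyl)phenyl on an aromatic carbon, and this step, an at least 19-fold higher number from compound 2 to compound 3 (1.29 log units; beyond the scatter), is the one readable step in this assay. The change from compound 2 to compound 1 is fluoro in place of trifluoromethyl on an aromatic carbon; its step that the two limits leave unreadable from compound 2 to compound 1 cannot be sized because the limit of < 5000 nM in this assay, at which 2 of the 3 values shown sit, holds both ends.

Compound 4, `Fc1ccc(Nc2cc3[nH]c(C4CCC(F)(F)CC4)nc3cn2)nc1`, is not yet measured. It differs from compound 3 as fluoro in place of trifluoromethyl on an aromatic carbon, the same change as that from compound 2 to compound 1, at a place described in the same words. The earlier instance gives no size, so the expectation for compound 4 rests mainly on compound 3 having 99000 nM as its starting point. The step expected from this change is a 1.4-fold higher number from compound 3 to compound 4 (0.15 log units; within the scatter), given as an estimate only. In this assay compound 4 is expected to give about 140000 nM, with a likely range from 50000 nM to 400000 nM.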

Compound 4, solubility: 170000 nM
For compound 4 the middle estimate is 1.2-fold (0.08 log units) below the measured one; measured number inside the range.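

On the core of compound 3, fluoro in place of trifluoromethyl gives a 1.7-fold higher number from compound 3 to compound 4 (0.23 log units; within the scatter) in this assay, so on this core the change leaves no readable difference. The same change from compound 2 to compound 1 cannot be sized, as both values are limits of the assay and not numbers: the limit of < 5000 nM in this assay, at which 2 of the 4 values shown sit. Among the compounds shown here, the series therefore holds only one readable instance of this change, which shows that it can sit within the scatter on one core but does not show that it would do so on the core of compound 1, and no comparison of size between the two cores is possible.

Going by these compounds, only fluoro and trifluoromethyl appear here on the aromatic carbon para to a large group, so the reading of an amine, a nitrile or a carboxylic acid at that place stays open. The other varied place carries only 4,4-difluorocyclohexyl or 3-(trifluoromethyl)phenyl, which leaves open how a longer chain or a morpholine there would read in this assay.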